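The source may report more compounds than this note shows. Statements on the series, on what has been measured and on what is new or still open speak of the compounds shown alone.

Compound 1 `COc1cc2c(cn1)Oc1ccc(NC(=O)c3ccc(Cl)cn3)cc1[C@@]21COC(N)=N1` was tested in an ADME assay on microsomes from liver (Homo sapiens) for metabolic stability, read by LC-MS, using NADPH, with a stated time of 30 min, tested at 1 uM; a lower number here means slower removal, a higher number faster removal of the compound. For compound 1 the assay reports only a limit, < 14 mL.min-1.g-1, rather than a number; this is the limit of < 14 mL.min-1.g-1 in this assay, at which 1 of the 3 values shown sits. Two further compounds were measured: compound 2 `NC1=N[C@@]2(CO1)c1cc(-c3cncc(C#CCO)c3)ccc1Oc1cnc(C3=CCOCC3)cc12` and compound 3 `NC1=N[C@@]2(CO1)c1cc(-c3cncc(C#CC4CC4)c3)ccc1Oc1cnc(C3=CCOCC3)cc12`. In this assay compound 2 gives 84 mL.min-1.g-1, and compound 3 gives 80 mL.min-1.g-1; the step of a 1.1-fold lower number from compound 2 to compound 3 (0.02 log units; within the scatter) lies within the scatter, and it concerns a different place in the molecule from the change followed here. Compound 4 `NC1=N[C@@]2(CO1)c1cc(NC(=O)c3ccc(Cl)cn3)ccc1Oc1cnc(C3CC3)cc12` differs from compound 1 by cyclopropyl in place of methoxy on an aromatic carbon. Within the data shown here, no measured step matches this change, so the step of an at least 1.7-fold higher number from compound 1 to compound 4 (0.25 log units; that floor lies within the scatter) is expected to be modest, though the expectation is uncertain. Compound 4 is therefore estimated at 25 mL.min-1.g-1, with a range from 10 mL.min-1.g-1 to 70 mL.min-1.g-1.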

Compound 4, intrinsic clearance in microsomes: < 14 mL.min-1.g-1
Compound 4 was reported as a limit (the forecaster's own chance of this, stated with the estimate: 30%); middle value at least 1.7-fold (0.25 log units) from the limit.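

Compound 1 and compound 4 both sit at a limit rather than a number in this assay, so no step between them can be read: the limit of < 14 mL.min-1.g-1 in this assay, at which 2 of the 4 values shown sit.

As far as these compounds go, whether cyclopropyl in place of methoxy changes the speed of removal at all stays open.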